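Swapping the Anilide Ring on an Inactive Compound

The compounds below may be only part of what the source reports. "The series", "measured", "known", "first", "only" and "open" are said of these compounds alone.

Compound 1 `O=C(CN1CCN(c2nnc(Cc3ccccc3)c3ccccc23)CC1)Nc1ccc(F)c(C(F)(F)F)c1`: 2480 nM
Compound 2 `Cc1ccc(F)cc1NC(=O)CN1CCN(c2nnc(Cc3ccccc3)c3ccccc23)CC1`: "not active" (no number reported)

Within the data shown here, in a functional assay on A549 cells (Homo sapiens) for cytotoxicity, read by MTT assay, with a stated time of 72 h (a lower number here means a stronger inhibitor, a higher number a weaker inhibitor), compound 2 has no number and is reported only as "not active" (no number reported), so no measured step links it to compound 1. Compound 3 `O=C(CN1CCN(c2nnc(Cc3ccccc3)c3ccccc23)CC1)Nc1ccc(F)c(F)c1` differs from compound 2 in one place. The change is 3,4-difluorophenyl in place of 5-fluoro-2-methylphenyl on an amide-type nitrogen: 3,4-difluorophenyl stands in place of 5-fluoro-2-methylphenyl on an amide-type nitrogen, and the shared core stays as it is. Among the measured compounds shown here, no measured pair shows this change. In this assay the step from compound 2 is expected to point towards stronger inhibition, but its size cannot be given without a number for compound 2. The closest guide is compound 1 at 2480 nM, and compound 3 is expected to land near or somewhat weaker than that, though it may also go without a number. The estimated value for compound 3 is 6000 nM, with an expected range of 2000 nM to 25000 nM.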

Compound 3, half-maximal inhibitory concentration: 10100 nM
Beside the measured number, compound 3's estimate is 1.7-fold (0.23 log units) below it; measured number inside the range.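

In this assay, the anilide ring of compound 3 carries a measured number, which shows that this position can hold a fluorinated phenyl ring and still give a readable value, although compound 2 has no number and the step from it to compound 3 cannot be read. The new comparison is on the aromatic carbon, where fluoro in place of trifluoromethyl gives a 4.1-fold higher number from compound 1 to compound 3 (0.61 log units; beyond the scatter), a weakening beyond the scatter. Nothing available explains this loss.

As far as these compounds go, it remains open whether a chloro group or a nitrile on that aromatic carbon would give a value nearer to compound 1 or to compound 3. The compounds shown also do not say how a methoxy group or a carboxylic acid would behave there.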